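Swapping the Aryl Group on the Amino Nitrogen

The compounds below may be only part of what the source reports. "The series", "measured", "known", "first", "only" and "open" are said of these compounds alone.

For the measured compounds named here, compound 2 `FC(F)(F)c1ccc(CSc2nc(Nc3cccc(Cl)c3)c3ccccc3n2)cc1` gives 19900 nM in a functional assay on HGC-27 cells (Homo sapiens) for cytotoxicity, read by MTT assay, with a stated time of 72 h (on this read-out higher numbers stand for weaker inhibition and lower numbers for stronger inhibition), the only number obtained in that assay. For compound 1 `FC(F)(F)c1ccc(CSc2nc(Nc3ccccc3Cl)c3ccccc3n2)cc1` this assay reports only a limit, > 50000 nM. Compound 3 `COc1ccc(Nc2nc(SCc3ccc(C(F)(F)F)cc3)nc3ccccc23)cc1` differs from compound 2 by 4-methoxyphenyl in place of 3-chlorophenyl on a nitrogen on an aromatic ring. Going by the values given here, the single measured step at this place, an at least 2.5-fold lower number from compound 1 to compound 2 (0.40 log units; beyond the scatter), moved the chlorine from one spot to another rather than exchanging it for a new group, so it guides the present change only loosely. Compound 3 is therefore expected to sit near compound 2, with an estimated 20000 nM, between 6000 nM and 50000 nM, a change of a 1.0-fold higher number from compound 2 to compound 3 (0.00 log units; within the scatter).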

Compound 3, half-maximal inhibitory concentration: 23500 nM
For compound 3 the middle estimate is 1.2-fold (0.07 log units) below the measured one, and the stated range covers the measured number.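

In this assay, the exchange of 3-chlorophenyl for 4-methoxyphenyl on the nitrogen gave a 1.2-fold higher number from compound 2 to compound 3 (0.07 log units; within the scatter), so a different group on this aryl ring, one that brings an oxygen, left the number unmoved. Replacing the 2-chlorophenyl with 4-methoxyphenyl gave an at least 2.1-fold lower number from compound 1 to compound 3 (0.32 log units; beyond the scatter), so two different groups now stand apart from the 2-chlorophenyl. Compound 1 is known only as a limit: the limit of > 50000 nM in this assay, at which 1 of the 3 values shown sits.

The compounds shown leave open whether an amine or a carboxylic acid on this aryl ring would move the number away from these values.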